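This account rests on a few compounds, and the source may have more. Where it says the series, first, only, none or still open, it means among the compounds named here.

Measured compounds in a functional assay on CHO-K1 cells for agonist activity at Glucose-dependent insulinotropic receptor (Homo sapiens), read by a luciferase reporter, with a stated time of 5 h; a lower number here means that less compound is needed, a higher number that more compound is needed for the effect:
Compound 1 `CC(C)OC(=O)N1CCC(Oc2ncnc3c2CCN3c2ccc(S(C)(=O)=O)cc2F)CC1` gives 50.1 nM.
Compound 2 `CS(=O)(=O)c1ccc(N2CCc3c(OC4CCN(C(=S)Sc5ccccc5)CC4)ncnc32)c(F)c1` gives 12.6 nM.
Compound 3 `CN(C)C(=O)CN1CCC(Oc2ncnc3c2CCN3c2ccc(S(C)(=O)=O)cc2F)CC1` gives only a limit of the assay, > 10000 nM.

Among these, compound 1 holds the highest of the two numbers reported; its nearest neighbour is compound 2, with a 4.0-fold lower number from compound 1 to compound 2 (0.60 log units; beyond the scatter). Compound 3 sits at the limit (the limit of > 10000 nM in this assay, at which 1 of the 3 values shown sits), so the step of an at least 190-fold higher number from compound 1 to compound 3 (2.30 log units; beyond the scatter) is known only as a bound. Both of these steps change the group on the amine nitrogen in a ring, and the same part of the core is involved in an at least 790-fold higher number from compound 2 to compound 3 (2.89 log units; beyond the scatter).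

Compound 4 `Cc1cc(S(C)(=O)=O)ccc1N1CCc2c(OC3CCN(C(=O)OC(C)C)CC3)ncnc21` is not yet measured. It differs from compound 1 elsewhere: methyl in place of fluoro on an aromatic carbon. The change sits on an aromatic carbon of a six-membered aromatic ring of carbon only, meta to a methylsulfonyl group, and leaves the amine nitrogen in a ring untouched. For the measured compounds named here, no measured step touches this position, so none of the three steps bears directly on it; what is known concerns a different part of the core. On this footing no step beyond the scatter is expected in this assay in either direction, though the evidence is thin. Compound 4 is therefore expected to give about 60 nM, between 20 nM and 200 nM. That estimate means a 1.2-fold higher number from compound 1 to compound 4 (0.08 log units; within the scatter), a step expected to lie within the scatter.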

Compound 4, half-maximal effective concentration: 100 nM
For compound 4 the middle estimate is 1.7-fold (0.22 log units) below the measured one, and the stated range covers the measured number.
By their numbers in this assay, from the lowest: compound 2; then compounds 1 and 4 (each within the scatter of the next). At a limit, above all of these: compound 3.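

In this assay, for the compounds shown here, methyl in place of fluoro on the aromatic carbon gives a 2.0-fold higher number from compound 1 to compound 4 (0.30 log units; within the scatter) and this pair is the only reading at this position, since the earlier steps all changed the group on the amine nitrogen in a ring. Compound 1 and compound 4 cannot be told apart in this assay, so in this one pair, at this place ortho to a large group and meta to a methylsulfonyl group, 2-fluoro-4-(methylsulfonyl)phenyl and 2-methyl-4-(methylsulfonyl)phenyl serve alike, whereas the steps beyond the scatter shown so far all lie at the amine nitrogen. Nothing measured here bears on the cause of this result.

The compounds shown leave open whether this position tolerates more than these two single-atom groups, for instance a chlorine, a methoxy group, an amine or a longer chain such as ethyl or propyl. Going by these compounds alone, they also leave open whether methyl in place of fluoro would read the same with another group on the amine nitrogen, such as the one carried by compound 2.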